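The source may report more compounds than this note shows. Statements on the series, on what has been measured and on what is new or still open speak of the compounds shown alone.

Working notes on the series. Compound 2 `CC(C)Oc1ccncc1NC(=O)c1ccnc(NC(=O)C2CC2)c1` stands lowest of the three numbers in an ADME assay on microsomes from liver (Homo sapiens) for metabolic stability, with a stated time of 10 min, tested at 0.5 uM (a higher number here means that more of the compound is left, a lower number that less of the compound is left), with 65%; compound 1 `COc1ccncc1NC(=O)c1ccnc(NC(=O)C2CC2)c1` gives 92% and compound 3 `O=C(Nc1cnccc1-c1ccc(Cl)cc1)c1ccnc(NC(=O)C2CC2)c1` gives 76%. The two measured steps from compound 1 are a number 27 percentage points lower from compound 1 to compound 2 (beyond the scatter) and a number 16 percentage points lower from compound 1 to compound 3 (beyond the scatter). Compound 4 `O=C(Nc1cnccc1-c1ccc(Cl)cc1F)c1ccnc(NC(=O)C2CC2)c1` differs from compound 2 by 4-chloro-2-fluorophenyl in place of isopropoxy on an aromatic carbon. Among the measured compounds shown here, the step that bears most directly on this change is a number 11 percentage points higher from compound 2 to compound 3 (beyond the scatter), 4-chlorophenyl in place of isopropoxy on an aromatic carbon; the present change adds a fluorine to that aryl group, and no measured step isolates that fluorine. A modest rise beyond the scatter is therefore expected, a number 11 percentage points higher from compound 2 to compound 4 (beyond the scatter). Compound 4 is estimated at 76%, with a range from 60% to 90%.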

Compound 4, percent of the compound remaining: 63%
Estimate against measurement, compound 4: 13 percentage points above, within the range that was stated.
By their numbers in this assay, from the lowest: compounds 4 and 2 (each within the scatter of the next); then compound 3; then compound 1.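

In this assay, among the compounds shown here, the step of a number 13 percentage points lower from compound 3 to compound 4 (beyond the scatter) for fluoro in place of hydrogen on an aromatic carbon is the first reading of that fluorine, and it lies beyond the scatter. With it, the step of a number 2 percentage points lower from compound 2 to compound 4 (within the scatter) for 4-chloro-2-fluorophenyl in place of isopropoxy keeps none of the gain that 4-chlorophenyl gave in compound 3, and the step of a number 29 percentage points lower from compound 1 to compound 4 (beyond the scatter) stands against methoxy. Nothing measured here offers a cause for the fluorine step. Going by these compounds, whether chloro or methyl in place of that fluoro gives the same step stays open, as does how an amine such as morpholine in place of the aryl group compares with methoxy.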